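A few compounds are considered here, and "the series" means these few. Any claim that something is new, unique, unknown or untested is made for them only; others in the source may bear on it.

In a functional assay on T47D cells (Homo sapiens) for antiproliferative activity, read by MTT assay, with a stated time of 72 h (on this read-out higher numbers stand for weaker inhibition and lower numbers for stronger inhibition), three compounds sharing one core have been measured. Compound 3 `COc1cccc(-n2ccnc2-c2cc(OC)c(OC)c(OC)c2)c1` gives 32200 nM, and compound 2 `COc1cc(-c2nccn2-c2cccc(C)c2)cc(OC)c1OC` gives 29300 nM, so the two sit level within the scatter. Compound 1 `COc1ccc(-n2ccnc2-c2cc(OC)c(OC)c(OC)c2)cc1[N+](=O)[O-]` gives 10000 nM, a lower number than compound 3 by a gap beyond the scatter.

Compound 4 `COc1cc(-c2nccn2-c2cccc([N+](=O)[O-])c2)cc(OC)c1OC` follows from compound 3 with nitro in place of methoxy on an aromatic carbon, meta to a large group: nitro in place of methoxy on an aromatic carbon. Going by the values given here, no measured step makes this exact change. Among the compounds with values here, the only step at this place is methoxy in place of methyl, a 1.1-fold higher number from compound 2 to compound 3 (0.04 log units; within the scatter), which shows that one exchange there left the number unmoved. Compound 1, at 10000 nM, also carries a nitro, but with a further methoxy, so it offers only a hint of a lower number.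

A small drop is therefore expected, not one clearly beyond the scatter. The estimated step is a 1.8-fold lower number from compound 3 to compound 4 (0.25 log units; within the scatter). Compound 4 is expected at 18000 nM, with an estimated range from 7000 nM to 40000 nM.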

Compound 4, half-maximal inhibitory concentration: 17900 nM
Estimate against measurement, compound 4: 1.0-fold (0.00 log units) above; measured number inside the range.
By their numbers in this assay, from the lowest: compounds 1, 4, 2 and 3 (each within the scatter of the next, the first and the last beyond it).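

In this assay, nitro in place of methoxy, meta to a large group, can now be read directly, and it gives a 1.8-fold lower number from compound 3 to compound 4 (0.26 log units; within the scatter), so this exchange stays within the scatter, as methoxy in place of methyl did. Nitro in place of methyl gives a 1.6-fold lower number from compound 2 to compound 4 (0.21 log units; within the scatter), so methyl, methoxy and nitro at this place all sit level, while hydrogen in place of methoxy gives a 1.8-fold higher number from compound 1 to compound 4 (0.25 log units; within the scatter), so the further methoxy of compound 1 does not set it apart from compound 4. Nothing available here explains why these numbers sit level.

On these data alone, whether an amine or a carboxylic acid at this place would move the number beyond the scatter remains open. Also open, as far as these compounds go, is whether a longer chain on the oxygen of the methoxy would do so.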